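The source may hold more compounds than are shown below. What is called first, only, known or untested is meant among the compounds shown, and "the series" means these compounds.

Measured compounds:
compound 1, `N/C(=N\NC(=S)N1CCOCC1)c1ccccn1`, 4700 nM
compound 2, `Cc1ccnc(/C(N)=N/NC(=S)N2CCOCC2)c1`, > 100000 nM
compound 3, `Cc1ccnc(/C(N)=N/NC(=S)N2CCN(c3ccccn3)CC2)c1`, 12300 nM

All three were tested in a functional assay on MCF7 cells (Homo sapiens) for cytotoxicity, read by MTT assay, with a stated time of 72 h; a higher number here means a weaker inhibitor, a lower number a stronger inhibitor. Compound 1 gives 4700 nM. For compound 2 the reading sits at the limit of > 100000 nM in this assay, at which 1 of the 3 values shown sits, so > 100000 nM is a limit of the assay and not a number. Compound 3 gives 12300 nM, the higher of the two numbers; the gap to compound 1 lies beyond the scatter, though no single change connects these two compounds.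

One change is made twice among these compounds. From compound 2 to compound 1 it reads hydrogen in place of methyl on an aromatic carbon and the step is an at least 21-fold lower number from compound 2 to compound 1 (1.32 log units; beyond the scatter). From compound 3 to the not yet measured compound 4, `N/C(=N\NC(=S)N1CCN(c2ccccn2)CC1)c1ccccn1`, it reads (hydrogen in place of methyl on an aromatic carbon); the place is described in the same words for both pairs, so it is the same change. The difference between the cores of compound 2 and compound 3 is not broken down here.

Among the measured compounds shown here, compound 4 is therefore expected to give a lower number than compound 3, because an at least 21-fold lower number from compound 2 to compound 1 (1.32 log units; beyond the scatter) shows what this change did in the one pair where it is measured; since that earlier step rests on a limit, its true size is unknown, and the expected step of a 4.9-fold lower number from compound 3 to compound 4 (0.69 log units; beyond the scatter) is set more cautiously. The estimate for compound 4 is 2500 nM, expected to fall between 700 nM and 9000 nM.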

Compound 4, half-maximal inhibitory concentration: 13700 nM
For compound 4 the middle estimate is 5.5-fold (0.74 log units) below the measured one; measured number above the stated range.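

In this assay, taking 4-methylpyridin-2-yl to pyridin-2-yl on the larger core gives a 1.1-fold higher number from compound 3 to compound 4 (0.05 log units; within the scatter), a step that lies within the scatter, so on this core the methyl group and the hydrogen cannot be told apart. Set beside the earlier step, the same change does not carry over from one core to the other in these compounds: the same change on two cores in this assay, an at least 21-fold lower number (1.32 log units; beyond the scatter) from compound 2 to compound 1 and a 1.1-fold higher number (0.05 log units; within the scatter) from compound 3 to compound 4, at least 23-fold (1.37 log units) apart, beyond the scatter of two such steps The reading of compound 2 is a limit of the assay and not a number, so the true size of the earlier step remains unknown, and with only one pair on each core nothing here shows which part of the core decides the outcome or how the change would behave on a further core.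

The compounds shown leave open how other groups would read in this assay at the same place opposite the ring nitrogen, such as an ethyl group, a methoxy group, a chlorine atom or an amine, on either core. They also leave open whether a third core would show a large step, as from compound 2 to compound 1, or a step within the scatter, as from compound 3 to compound 4.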